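A few compounds are considered here, and "the series" means these few. Any claim that something is new, unique, unknown or untested is made for them only; others in the source may bear on it.

In a functional assay on CCRF-CEM cells (Homo sapiens) for inhibition, read by MTT assay, with a stated time of 4 days (a lower number here means a stronger inhibitor, a higher number a weaker inhibitor), compound 1 `COc1cc(NC(C)CCCNC(=O)NNC(=O)NCCCCCO)c2ncccc2c1` gives 170000 nM. Compound 2 `COc1cc(NC(C)CCCNC(=O)NNC(=O)NC(CO)(CO)CO)c2ncccc2c1` gives > 250000 nM, which is a limit and not a number, and this is the limit of > 250000 nM in this assay, at which 1 of the 2 values shown sits. Within the data shown here, the only measured step is an at least 1.4-fold higher number from compound 1 to compound 2 (0.16 log units; that floor lies within the scatter). Compound 3 `COc1cc(NC(C)CCCNC(=O)Nc2ccc(Cl)c(C(F)(F)F)c2)c2ncccc2c1` differs from compound 2 in one place: 4-chloro-3-(trifluoromethyl)phenyl in place of ((2-hydroxy-1,1-bis(hydroxymethyl)ethyl)carbamoyl)amino on an amide-type nitrogen. The measured step only exchanges one hydroxy-bearing chain for another, so it offers little guide to a change that brings in an aromatic ring. A move towards stronger inhibition is nevertheless expected, with an estimated at least 12-fold lower number from compound 2 to compound 3 (1.09 log units; beyond the scatter). Compound 3 is expected at 20000 nM, within an estimated range of 4000 nM to 100000 nM.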

Compound 3, half-maximal inhibitory concentration: 3100 nM
For compound 3 the middle estimate is 6.5-fold (0.81 log units) above the measured one; the measured number lies below the stated range.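

In this assay, an aromatic ring on this amide-type nitrogen brings a large change: 4-chloro-3-(trifluoromethyl)phenyl in place of ((5-hydroxypentyl)carbamoyl)amino gives a 55-fold lower number from compound 1 to compound 3 (1.74 log units; beyond the scatter). The same group in place of ((2-hydroxy-1,1-bis(hydroxymethyl)ethyl)carbamoyl)amino gives an at least 80-fold lower number from compound 2 to compound 3 (1.90 log units; beyond the scatter), which is only a floor. Compound 2 has a limit and not a number: the limit of > 250000 nM in this assay, at which 1 of the 3 values shown sits.

Only one aromatic group is shown, so it stays open whether the ring alone carries this gain or whether its chlorine and trifluoromethyl also contribute. Plain phenyl, a 4-chlorophenyl or a phenyl bearing a carboxylic acid would begin to separate these.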